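Urea-to-thiourea change on the ring amine nitrogen

The source may hold more compounds than are shown below. What is called first, only, known or untested is meant among the compounds shown, and "the series" means these compounds.

Among the measured compounds shown here, compound 1 `O=C(Nc1ccc(F)cc1)N1CCN(S(=O)(=O)c2sccc2-c2ccccc2Oc2ccc(O)c(O)c2)CC1` gives 8100 nM in a functional assay on HL-60 cells (Homo sapiens) for inhibition, read by CCK-8 assay, with a stated time of 48 h (on this read-out higher numbers stand for weaker inhibition and lower numbers for stronger inhibition), and is the only member of the series with a number rather than a limit. Compound 2 `COc1ccc(Oc2ccccc2-c2ccsc2S(=O)(=O)N2CCN(C(=O)Nc3ccc(F)cc3)CC2)cc1OC` is reported in this assay only as a limit, > 20000 nM. For the measured compounds named here, the single measured step, an at least 2.4-fold higher number from compound 1 to compound 2 (0.39 log units; beyond the scatter), sits at the oxygen on an aromatic ring and rests on (the limit of > 20000 nM in this assay, at which 1 of the 2 values shown sits); it says nothing about the piperazine side of the molecule. Compound 3 `O=[N+]([O-])c1ccc(NC(=S)N2CCN(S(=O)(=O)c3sccc3-c3ccccc3Oc3ccc(O)c(O)c3)CC2)cc1` differs from compound 1 by a group of 12 heavy atoms (7 carbon, 2 nitrogen, 2 oxygen, 1 sulfur; one six-membered aromatic ring of carbon only) in place of a group of 10 heavy atoms (7 carbon, 1 nitrogen, 1 oxygen, 1 fluorine; one six-membered aromatic ring of carbon only), on an amine nitrogen in a ring, the change being on an amine nitrogen in a ring. Going by the values given here, no measured step touches that position, so the expectation rests on compound 1 alone, and the step expected in this assay is a 1.0-fold lower number from compound 1 to compound 3 (0.01 log units; within the scatter), none beyond the scatter. Compound 3 is therefore estimated at 8000 nM in this assay, with a range from 2500 nM to 25000 nM and a real chance that only a limit is reported.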

Compound 3, half-maximal inhibitory concentration: 5300 nM
Estimate against measurement, compound 3: 1.5-fold (0.18 log units) above; the range from low to high includes it.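

The ring amine nitrogen now has its first measured step, in this assay: a 1.5-fold lower number from compound 1 to compound 3 (0.18 log units; within the scatter). The group on this nitrogen can therefore be exchanged for one that differs at two points, sulfur for the carbonyl oxygen and nitro for fluorine on the phenyl ring, with the two numbers staying within the scatter of each other. Nothing shown gives a reason for this outcome.

With both points changed at once, the step cannot show whether each change alone is silent or whether the two offset each other. On these data alone, the 4-fluorophenyl thiourea and the 4-nitrophenyl urea would separate them, while a simple acetyl group or a carboxylic acid on the phenyl ring would test how far this position stays open to change.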